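Nitrile to Amide at One Position of a Shared Core

The source may report more compounds than this note shows. Statements on the series, on what has been measured and on what is new or still open speak of the compounds shown alone.

Measured in a physicochemical assay for solubility, using the shake flask method, measured as kinetic solubility, with a stated time of 20 h, at pH 2; on this read-out lower numbers stand for lower solubility and higher numbers for higher solubility:
Compound 1, `COc1ccc(Nc2cc3[nH]c(-c4cccc(C(F)(F)F)c4)nc3cn2)nc1`, gives only a limit, < 5000 nM.
Compound 2, `N#Cc1ccc(Nc2cc3[nH]c(-c4cccc(C(F)(F)F)c4)nc3cn2)nc1`, gives only a limit, < 5000 nM.

Compound 2 carries a cyano group on the six-membered aromatic ring with 1 nitrogen, and its result in this assay is a limit rather than a number. Going by the values given here, the only measured change on this core, a step that the two limits leave unreadable from compound 1 to compound 2, cannot be sized, since (the limit of < 5000 nM in this assay, at which 2 of the 2 values shown sit), and so it gives no direction for the next step.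

Compound 3 is `NC(=O)c1ccc(Nc2cc3[nH]c(-c4cccc(C(F)(F)F)c4)nc3cn2)nc1`. It differs from compound 2 by carbamoyl in place of cyano on an aromatic carbon. No measured step of this kind exists among the compounds shown, and the one available step is itself unreadable. The expectation for compound 3 in this assay therefore rests only on where compound 2 stands, and the step that the limit leaves unreadable from compound 2 to compound 3 is expected to be no larger than the scatter, with a sizeable chance that the assay again reports only a limit. The estimate for compound 3 is 3000 nM, with a range from 500 nM to 15000 nM.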

Compound 3, solubility: < 5000 nM
Compound 3 gave a limit, no number; the forecaster's own chance of this, stated with the estimate: 65%; the middle value lies beyond the limit too.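

No size can be put on any step among compound 1, compound 2 and compound 3 in this assay, because each result is a limit and not a number: the limit of < 5000 nM in this assay, at which 3 of the 3 values shown sit.

The compounds shown leave open how the methoxy, cyano and carbamoyl groups compare in this assay, and whether replacing one with another changes the result at all.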